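Stability of the bis(trifluoromethyl)aryl series: fluoro to sulfanyl

This account rests on a few compounds, and the source may have more. Where it says the series, first, only, none or still open, it means among the compounds named here.

Measured so far:
compound 1, `C=CS(=O)(=O)c1cc(C(F)(F)F)cc(C(F)(F)F)c1`: < 0.017 h
compound 2, `Fc1cc(C(F)(F)F)cc(C(F)(F)F)c1`: > 50 h

In an ADME assay for pharmacokinetics, read by LC-MS, in phosphate buffer, with a stated time of 72 h, at pH 7.4, tested at 250 uM (a higher number here means that the compound lasts longer, a lower number that the compound disappears faster), compound 2 gives only a limit, > 50 h. Compound 1 likewise gives only a limit, < 0.017 h. For the measured compounds named here, the one measured step, an at least 2900-fold higher number from compound 1 to compound 2 (3.46 log units; beyond the scatter), is large but concerns a different group than the change now in hand. Compound 3, `FC(F)(F)c1cc(S)cc(C(F)(F)F)c1`, differs from compound 2 by sulfanyl in place of fluoro on an aromatic carbon. Going by the values given here, no measured step matches this exchange, so the direction is open. For compound 3 the estimate is a step of an at least 2.5-fold lower number from compound 2 to compound 3 (0.39 log units; beyond the scatter) in this assay, expected to give about 20 h, within 3 h to 60 h.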

Compound 3, half-life: > 50 h
Compound 3 was reported as a limit (the forecaster's own chance of this, stated with the estimate: 35%); middle value at least 2.5-fold (0.39 log units) away from the limit.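

In this assay compound 3 gives > 50 h, which is a limit of the assay. Swapping the vinylsulfonyl group for the sulfanyl group gives an at least 2900-fold higher number from compound 1 to compound 3 (3.46 log units; beyond the scatter), so the long-lasting end of the series is no longer held by the fluoro compound alone. The step between compound 2 and compound 3 cannot be read, and both stand at the same limit: the limit of > 50 h in this assay, at which 2 of the 3 values shown sit.

On these data alone, how far compound 2 and compound 3 lie apart stays open. Also open, as far as these compounds go, is whether an amine or a carboxylic acid at this position would reach the same limit.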